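A few compounds are considered here, and "the series" means these few. Any claim that something is new, unique, unknown or untested is made for them only; others in the source may bear on it.

Working notes on the series. In a functional assay on Fem-X cells (Homo sapiens) for cytotoxicity (on this read-out higher numbers stand for weaker inhibition and lower numbers for stronger inhibition), compound 1 `CCCCSC1=CC(=O)C(C[C@]2(C)[C@@H](C)CC[C@]3(C)C(C)=CCC[C@@H]23)=CC1=O` gives 24400 nM. Compound 2 `COC1=CC(=O)C=C(C[C@]2(C)[C@@H](C)CC[C@]3(C)C(C)=CCC[C@@H]23)C1=O` gives 9800 nM in this assay, and compound 3 `CC1CCC[C@H]2[C@](C)(CC3=CC(=O)C(Cl)=CC3=O)[C@@H](C)CC[C@]12C` gives 32200 nM. Among these three numbers compound 1 stands second highest; its gap to compound 3 lies within the scatter, while compound 2 sits beyond the scatter with the lower number. Within the data shown here, no pair among the measured compounds differs in a single place, so no step is at hand. Compound 4 `CCCSC1=CC(=O)C(C[C@]2(C)[C@@H](C)CC[C@]3(C)C(C)=CCC[C@@H]23)=CC1=O` differs from compound 1 by hydrogen in place of methyl on a saturated chain carbon, three bonds along the chain from a sulfur. The step is expected to be small, estimated as a 1.1-fold lower number from compound 1 to compound 4 (0.03 log units; within the scatter), not beyond the scatter in either direction. For compound 4 the expected value in this assay is 23000 nM, estimated range 10000 nM to 50000 nM.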

Compound 4, half-maximal inhibitory concentration: 89500 nM
For compound 4 the middle estimate is 3.9-fold (0.59 log units) below the measured one; the whole stated range lies below it.
By their numbers in this assay, from the lowest: compound 2; then compounds 1 and 3 (each within the scatter of the next); then compound 4.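

In this assay, going from butyl to propyl, with hydrogen in place of methyl on a saturated chain carbon, three bonds along the chain from a sulfur, gives a 3.7-fold higher number from compound 1 to compound 4 (0.56 log units; beyond the scatter). Among these compounds, this position therefore responds to a change of a single carbon, which the earlier compounds, with no pair differing in one place, could not show. No measurement at hand accounts for the step. As far as these compounds go, one step sets no trend with chain length: whether ethyl or a longer chain such as pentyl would follow the same direction stays open.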